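1,3-Thiazol-2-yl in Place of Pyridin-4-yl: Expected Clearance

A few compounds are considered here, and "the series" means these few. Any claim that something is new, unique, unknown or untested is made for them only; others in the source may bear on it.

Of the compounds shown here, three built on the same core have been measured in an ADME assay on microsomes from liver (Mus musculus) for metabolic stability; on this read-out lower numbers stand for slow clearance and higher numbers for fast clearance. Compound 1 `CN1C(=O)C2=C(C1=O)N(CC(=O)Nc1ccc(-c3ccncc3)cc1)CCC2` gives 44 mL.min-1.g-1 in this assay. Compound 2 `CN1C(=O)C2=C(C1=O)N(CC(=O)Nc1ccc(-c3cccnc3)nn1)CCC2` gives 12 mL.min-1.g-1, and compound 3 `CN1C(=O)C2=C(C1=O)N(CC(=O)Nc1ccc(-c3ccccc3)nc1)CCC2` gives 13 mL.min-1.g-1. Compound 1 therefore stands highest of the three numbers: compound 3 is the nearest to it, yet its lower number lies beyond the usual scatter, and compound 2 is the furthest, also beyond the scatter. Among these three, compound 1 is the one cleared fastest.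

Compound 4 `CN1C(=O)C2=C(C1=O)N(CC(=O)Nc1ccc(-c3nccs3)cc1)CCC2` has not yet been measured in this assay. It differs from compound 1 in one place on the shared core: 1,3-thiazol-2-yl in place of pyridin-4-yl on an aromatic carbon. For the measured compounds named here, none of the measured pairs shows this exact change, so there is no measured step that speaks directly to it, and the expectation has to rest on compound 1 alone.

The expectation is that compound 4 stays close to compound 1, with a step that does not clearly exceed the usual scatter, expressed as a 1.3-fold lower number from compound 1 to compound 4 (0.10 log units; within the scatter). Compound 4 is accordingly estimated at 35 mL.min-1.g-1 in this assay. The estimate for compound 4 spans from 15 mL.min-1.g-1 to 80 mL.min-1.g-1.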

Compound 4, intrinsic clearance in microsomes: 65 mL.min-1.g-1
For compound 4 the middle estimate is 1.9-fold (0.27 log units) below the measured one, and the stated range covers the measured number.
By their numbers in this assay, from the lowest: compounds 2 and 3 (each within the scatter of the next); then compounds 1 and 4 (each within the scatter of the next).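

In this assay, putting 1,3-thiazol-2-yl in place of pyridin-4-yl on an aromatic carbon, para to a large group, gives a 1.5-fold higher number from compound 1 to compound 4 (0.17 log units; within the scatter), and this is the first step shown at this position. The result shows that, on the shared core, a six-membered aromatic ring with 1 hetero atom can be exchanged for a smaller five-membered aromatic ring with 2 hetero atoms, one of them sulfur, with no difference beyond the usual scatter in this read-out. Nothing available here speaks to what lies behind this result.

Going by these compounds, with only these two groups to compare at this position, it remains open how this assay would read with a group of a different kind on the same aromatic carbon, such as an amine, a carboxylic acid or a morpholine ring. On these data alone, it is also open whether this exchange would give a step of similar size if the six-membered ring that carries it contained nitrogen rather than carbon only.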